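The source may report more compounds than this note shows. Statements on the series, on what has been measured and on what is new or still open speak of the compounds shown alone.

Working notes on the series, read in a functional assay on MCF7 cells (Homo sapiens) for cytotoxicity, read by MTT assay, with a stated time of 4 days; a higher number here means a weaker inhibitor, a lower number a stronger inhibitor.

Compound 1, `C=C1C[C@]23C[C@@]1(O)CC[C@H]2c1ccc(O)c(C)c1[C@@H]3Cn1cc(-c2ccc(C(F)(F)F)cc2)nn1`, gives 12400 nM in this assay. Among the measured compounds shown here, compound 2, `C=C1C[C@]23C[C@@]1(O)CC[C@@H]2c1cccc(C)c1[C@@H]3Cn1cc(-c2ccc(OC)cc2)nn1`, differs from compound 1 in more than one place, so no single step between the two is taken here; the two values stand side by side without a step. For compound 2 this assay reports only a limit, > 20000 nM, and no number. That is the limit recorded as the limit of > 20000 nM in this assay, at which 1 of the 2 values shown sits, so compound 2 has no measured figure of its own to build on.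

Compound 3, `C=C1C[C@]23C[C@@]1(O)CC[C@@H]2c1cccc(C)c1[C@@H]3Cn1cc(-c2ccc(Cl)cc2)nn1`, follows from compound 2 by chloro in place of methoxy on an aromatic carbon. For the measured compounds named here, no measured step shows the effect of this change, and compound 1 differs from compound 2 elsewhere in the structure as well, so its value does not fix the step. The step from compound 2 to compound 3 is expected to be small, an at least 1.3-fold lower number from compound 2 to compound 3 (0.12 log units; that floor lies within the scatter), of uncertain direction and most likely within the scatter. For compound 3 the estimate in this assay is 15000 nM, within 5000 nM to 40000 nM, with a fair chance that only a limit is again reported.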

Compound 3, half-maximal inhibitory concentration: > 20000 nM
Compound 3: only a limit was reported (the forecaster's own chance of this, stated with the estimate: 45%); at least 1.3-fold (0.12 log units) between middle value and limit.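

Compound 2 and compound 3 both give only a limit in this assay, so no step between them can be read: the limit of > 20000 nM in this assay, at which 2 of the 3 values shown sit.

The compounds shown leave open whether 4-chlorophenyl in place of 4-methoxyphenyl changes the number in this assay at all, and in which direction.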